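The source may hold more compounds than are shown below. What is called first, only, known or untested is meant among the compounds shown, and "the series" means these compounds.

Measured in a functional assay on HeLa cells (Homo sapiens) for cytotoxicity, read by MTT assay, with a stated time of 48 h (a lower number here means a stronger inhibitor, a higher number a weaker inhibitor), so far:
- compound 1 `N#Cc1ccc(Cn2c(/C=C3\SC(=S)N(CC(=O)O)C3=O)nc3ccccc32)cc1` gives 16300 nM
- compound 2 `Cc1ccc(Cn2c(/C=C3\SC(=S)N(CC(=O)O)C3=O)nc3ccccc32)cc1` gives 1280 nM
- compound 3 `O=C(O)CN1C(=O)/C(=C/c2nc3ccccc3n2Cc2cccc(F)c2)SC1=S` gives > 50000 nM as a limit of the assay, not a number

Compound 2 holds the lower of the two actual numbers, and compound 1 holds the other (a 13-fold lower number from compound 1 to compound 2 (1.10 log units; beyond the scatter)). Compound 3 stands only at a limit (the limit of > 50000 nM in this assay, at which 1 of the 3 values shown sits).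

Compound 4 `Cc1ccc(Cn2c(/C=C3\SC(=S)N(CC(=O)O)C3=O)nc3ccc(Cl)cc32)cc1` departs from compound 2 at one place on the shared core (chloro in place of hydrogen on an aromatic carbon): chloro in place of hydrogen on an aromatic carbon, in the six-membered aromatic ring of carbon only that is part of the fused system.

Within the data shown here, no measured step touches this carbon. All three change the substituted phenyl group instead, and two of them are large (a 13-fold lower number from compound 1 to compound 2 (1.10 log units; beyond the scatter) and an at least 39-fold higher number from compound 2 to compound 3 (1.59 log units; beyond the scatter)), with a smaller one between compounds 1 and 3 (an at least 3.0-fold higher number from compound 1 to compound 3 (0.48 log units; beyond the scatter)). Among these three compounds, then, the number in this assay moves widely with single changes, but the steps give no direction for the new chloro. A central shift within the scatter is expected, with a wide margin on both sides and somewhat more room towards higher numbers.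

The expected step is small (a 1.2-fold higher number from compound 2 to compound 4 (0.07 log units; within the scatter)).

For compound 4 the estimated value is 1500 nM with an expected range from 350 nM to 8000 nM in this assay.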

Compound 4, half-maximal inhibitory concentration: 11000 nM
Beside the measured number, compound 4's estimate is 7.3-fold (0.87 log units) below it; measured number above the stated range.
By their numbers in this assay, from the lowest: compound 2; then compounds 4 and 1 (each within the scatter of the next). At a limit, above all of these: compound 3.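

In this assay, among these compounds, the first measured change on this carbon of the shared core gives an 8.6-fold higher number from compound 2 to compound 4 (0.93 log units; beyond the scatter) and shows that the number depends on more than the substituted phenyl group, which was the only part varied in the earlier steps. On this single pair, replacing hydrogen with chloro at this carbon, in the six-membered aromatic ring of carbon only that is part of the fused system, moves the compound towards weaker inhibition, so the position cannot be treated as a free place for adding a substituent while the 4-methylphenyl group is present. Nothing shown here gives a reason for this step.

One pair cannot show whether the loss belongs to chloro itself or to any group on this carbon, and fluoro, methyl, methoxy or an amine in the same place would separate those two readings. On these data alone, it also remains open whether the same step appears with the 4-cyanophenyl or 3-fluorophenyl group in place of the 4-methylphenyl group, and whether other carbons of this ring respond in the same direction.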